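Swapping Pyridinyl for Phenyl on the Piperazine Amide

A few compounds are considered here, and "the series" means these few. Any claim that something is new, unique, unknown or untested is made for them only; others in the source may bear on it.

The measured compounds:
- compound 1, `COc1ccc(C[C@@H](O)/C=C/C=C/C(=O)NCc2ccccc2)cc1OC`, gives 16600 nM in a functional assay on IMR-32 cells (Homo sapiens) for antiproliferative activity, read by sulforhodamine B assay, with a stated time of 48 h; a lower number here means a stronger inhibitor, a higher number a weaker inhibitor
- compound 2, `COc1ccc(CNC(=O)/C=C/C=C/[C@H](O)Cc2ccc(OC)c(OC)c2)cc1`, gives 17400 nM in this assay
- compound 3, `COc1ccc(C[C@@H](O)/C=C/C=C/C(=O)N2CCN(c3ccccn3)CC2)cc1OC`, gives 11100 nM in this assay

Compound 3 has the lowest of the three numbers in this assay, but its distance to compound 1 and to compound 2 lies within the scatter, so the three compounds cannot be ordered from these values.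

The new compound is compound 4, `COc1ccc(C[C@@H](O)/C=C/C=C/C(=O)N2CCN(c3ccccc3)CC2)cc1OC`. It differs from compound 3 in one place: phenyl in place of pyridin-2-yl on an amine nitrogen in a ring.

Within the data shown here, only one measured step exists, a 1.0-fold higher number from compound 1 to compound 2 (0.02 log units; within the scatter). It concerns a methoxy in place of hydrogen on an aromatic carbon, far from the amine nitrogen in the ring where compound 4 changes, so it says nothing direct about the present change. Among the measured compounds shown here, the data hold no pair in which a pyridin-2-yl is replaced by a phenyl. With a single within-scatter step available, no movement beyond the scatter is expected in this assay.

Compound 4 is therefore estimated at 11000 nM, with a range from 5000 nM to 25000 nM, and the expected step is a 1.0-fold lower number from compound 3 to compound 4 (0.00 log units; within the scatter).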

Compound 4, half-maximal inhibitory concentration: 9430 nM
For compound 4 the middle estimate is 1.2-fold (0.07 log units) above the measured one; measured number inside the range.
By their numbers in this assay, from the lowest: compounds 4, 3, 1 and 2 (each within the scatter of the next).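

In this assay, among these compounds, phenyl in place of pyridin-2-yl on the amine nitrogen in the ring gives a 1.2-fold lower number from compound 3 to compound 4 (0.07 log units; within the scatter), the first measured step at this place. The two aromatic rings have the same size and differ in one hetero atom and one hydrogen-bond acceptor, yet compound 3 and compound 4 cannot be told apart in this read-out, so for this pair that ring nitrogen makes no difference that the measurement can resolve. No measured finding at hand bears on why these two groups read alike.

On these data alone, it remains open whether this tolerance extends to groups of another kind on the same amine nitrogen, such as a cyclohexyl ring, a benzyl group, or a phenyl carrying a methoxy, a chlorine or a carboxylic acid. Since every number shown lies in one narrow band, it also remains open whether any change at this place can move the antiproliferative read-out beyond the scatter at all.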